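Shortening the Amino Acid Side Chain: A Forecast

This account rests on a few compounds, and the source may have more. Where it says the series, first, only, none or still open, it means among the compounds named here.

Compound 1, `O=C(O)CNC(=O)CN(c1nc(Cl)nc2[nH]cnc12)C1CC1`: 32.2%
Compound 2, `NC(=O)CC[C@H](NC(=O)CN(c1nc(Cl)nc2[nH]cnc12)C1CC1)C(=O)O`: 33.1%

Both compounds were run in a functional assay on the whole organism (Tail, strain ICR) with Mus musculus as the target, in the tail flick test, with a stated time of 30 min, at a dose of 25 umol/kg by the oral route; a higher number here means a stronger effect of the compound at the dose given, a lower number a weaker effect. Compound 2 gives 33.1% there, nominally the larger of the two numbers, yet the gap to compound 1 is within the scatter: the step of a number 0.9 percentage points higher from compound 1 to compound 2 (within the scatter) shows that placing a 2-carbamoylethyl group on the chain carbon made no difference that can be trusted. Compound 3, `C[C@H](NC(=O)CN(c1nc(Cl)nc2[nH]cnc12)C1CC1)C(=O)O`, is not yet measured. It differs from compound 2 thus: hydrogen in place of carbamoylmethyl on a saturated chain carbon, two bonds along the chain from an amide-type nitrogen and a carbonyl carbon. Going by the values given here, the only measured step that bears on this change is a number 0.9 percentage points higher from compound 1 to compound 2 (within the scatter), and since that step stayed within the scatter, no change beyond the scatter is expected in this assay either. Compound 3 is therefore expected to give 32%, with a range of 18% to 46%. That expectation amounts to a step of a number 1.1 percentage points lower from compound 2 to compound 3 (within the scatter).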

Compound 3, a percentage reported as activity, at one dose (the size of the read-out at that dose, not a potency): 48.1%
The estimate for compound 3 lay 16.1 percentage points below the measured number; the measured number lies above the stated range.
By their numbers in this assay, from the lowest: compounds 1 and 2 (each within the scatter of the next); then compound 3.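

In this assay this saturated chain carbon proves sensitive to what it carries, which the earlier pair did not reveal: replacing carbamoylmethyl with hydrogen, which cuts the 2-carbamoylethyl group back to methyl, gives a number 15 percentage points higher from compound 2 to compound 3 (beyond the scatter) and so a change that can be trusted. Methyl also separates itself from hydrogen at this carbon, with a number 15.9 percentage points higher from compound 1 to compound 3 (beyond the scatter) as the step, whereas 2-carbamoylethyl in place of hydrogen stayed within the scatter, so the effect at this position depends on which group is present and not merely on whether one is present. No measurement shown here accounts for this difference.

The compounds leave open whether an ethyl or propyl chain without the terminal carbamoyl group would behave like methyl or like 2-carbamoylethyl. They also leave open how a side chain ending in an amine or a carboxylic acid would read at this carbon.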